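Amide nitrogen substituents and cytotoxicity across the series

The compounds below may be only part of what the source reports. "The series", "measured", "known", "first", "only" and "open" are said of these compounds alone.

Measured so far:
compound 1 `C=CC1=C(C(=O)NC(C)(C)C)C(c2ccc(OC)cc2)OC1` — > 100000 nM (a limit)
compound 2 `C=CC1=C(C(=O)Nc2ccc(OCC)cc2)C(c2ccc(OC)cc2)OC1` — > 100000 nM (a limit)

In a functional assay on QGY7701 cells (Homo sapiens) for cytotoxicity, read by MTT assay, with a stated time of 24 h (on this read-out lower numbers stand for stronger inhibition and higher numbers for weaker inhibition), compound 1 reaches only the limit of the assay, > 100000 nM. Compound 2 likewise returns only a limit in this assay, > 100000 nM. The step that the two limits leave unreadable from compound 1 to compound 2 is therefore unreadable; compound 2 stands at the limit, as does every value shown, in line with the limit of > 100000 nM in this assay, at which 2 of the 2 values shown sit.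

Compound 3 `C=CC1=C(C(=O)NCc2ccccc2F)C(c2ccc(OC)cc2)OC1` differs from compound 2 by 2-fluorobenzyl in place of 4-ethoxyphenyl on an amide-type nitrogen. Among the compounds with values here, no measured step speaks to this change with a readable size: the only step available, a step that the two limits leave unreadable from compound 1 to compound 2, is itself unreadable, and both groups tried so far on the amide-type nitrogen left the read-out at the limit. In this assay the step that the limit leaves unreadable from compound 2 to compound 3 is expected to stay within the scatter, with the result most likely again a limit. Compound 3 is estimated at 150000 nM, with a range from 30000 nM to 600000 nM.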

Compound 3, half-maximal inhibitory concentration: > 100000 nM
Compound 3 was reported as a limit; the forecaster's own chance of this, stated with the estimate: 75%; the middle value does not contradict the limit.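

In this assay, within the data shown here, no step among compound 1, compound 2 and compound 3 can be read, as all three are reported only as a limit: the limit of > 100000 nM in this assay, at which 3 of the 3 values shown sit.

The compounds shown leave open whether any group on the amide-type nitrogen, or any change elsewhere on the shared core, brings the read-out off this limit.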